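Substituted benzyl groups on a sulfonylurea core for orexin binding

This account rests on a few compounds, and the source may have more. Where it says the series, first, only, none or still open, it means among the compounds named here.

Measured compounds:
Compound 1 `COc1ccc(N2C(=O)N(Cc3c(F)cc(F)cc3OC)c3ccccc3S2(=O)=O)cc1OC` gives 6.31 nM in an assay on HEK293 cells for displacement of a labelled ligand from Orexin receptor type 2 (Homo sapiens), read by scintillation counting, with a stated time of 90 min; a lower number here means a stronger inhibitor, a higher number a weaker inhibitor.
Compound 2 `COc1ccc(N2C(=O)N(Cc3ccccc3)c3ccccc3S2(=O)=O)cc1OC` gives 79.4 nM in this assay.
Compound 3 `COc1cc(N2C(=O)N(Cc3c(F)cc(F)cc3F)c3ccccc3S2(=O)=O)cc(OC)n1` gives 1.26 nM in this assay.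

Compound 2 stands highest of the three numbers in this assay; compound 1 lies nearest and compound 3 furthest from it, both beyond the scatter. Compound 4 `COc1ccc(N2C(=O)N(Cc3c(F)cc(C)cc3Cl)c3ccccc3S2(=O)=O)cc1OC` differs from compound 2 in one place: 2-chloro-6-fluoro-4-methylphenyl in place of phenyl on a saturated chain carbon bound to an amide-type nitrogen in a ring. The step that bears on this change is a 13-fold higher number from compound 1 to compound 2 (1.10 log units; beyond the scatter), which shows that removing the substituents from the benzyl ring raised the number strongly. Restoring a fully substituted benzyl in compound 4 is therefore expected to move the number back down, and a step of about a 13-fold lower number from compound 2 to compound 4 (1.12 log units; beyond the scatter) is expected. Compound 4 is estimated at 6 nM, with a range from 2 nM to 20 nM.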

Compound 4, inhibition constant: 0.794 nM
Beside the measured number, compound 4's estimate is 7.6-fold (0.88 log units) above it; measured number outside the range, below it.
By their numbers in this assay, from the lowest: compounds 4 and 3 (each within the scatter of the next); then compound 1; then compound 2.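

In this assay the 2-chloro-6-fluoro-4-methylbenzyl group brings a 100-fold lower number from compound 2 to compound 4 (2.00 log units; beyond the scatter) and, set against a differently substituted benzyl group, a 7.9-fold lower number from compound 1 to compound 4 (0.90 log units; beyond the scatter) as well. The number at this place on the amide-type nitrogen therefore depends on which substituents the benzyl ring carries, not only on whether it carries any. Nothing given here accounts for the difference between these two substituted benzyl groups. The compounds shown leave open which of the chloro, fluoro and methyl substituents carries the step, and how a benzyl ring bearing an amine or a carboxylic acid would read at this place.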